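Cyclopropyl for cyano on the oxadiazole: microsomal half-life

The source may hold more compounds than are shown below. What is called first, only, known or untested is meant among the compounds shown, and "the series" means these compounds.

Measured compounds:
compound 1, `Cc1cc(CCCOc2c(C)cc(-c3noc(C)n3)cc2C)on1`, 0.45 h
compound 2, `Cc1cc(CCCOc2c(C)cc(-c3noc(C#N)n3)cc2C)on1`, 0.283 h

Both compounds share the same core and differ only in the group on the five-membered aromatic ring. In an in vitro ADME assay on microsomes from liver (Simiiformes) (on this read-out lower numbers stand for a shorter-lived compound and higher numbers for a longer-lived compound), compound 1 gives 0.45 h, while compound 2 gives 0.283 h. Among the compounds with values here, the single step between them, a 1.6-fold lower number from compound 1 to compound 2 (0.20 log units; within the scatter), is within the scatter, so compound 2 holds the lowest of the two numbers only nominally and cannot be called shorter-lived than compound 1.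

Compound 3, `Cc1cc(CCCOc2c(C)cc(-c3noc(C4CC4)n3)cc2C)on1`, is not yet measured. Its difference from compound 2 is cyclopropyl in place of cyano on an aromatic carbon. Within the data shown here, the only measured step that bears on this position is the one from compound 1 to compound 2, and that step was within the scatter. On that basis the step in this assay from compound 2 to compound 3 is expected to be small, at most a modest rise, a 1.4-fold higher number from compound 2 to compound 3 (0.15 log units; within the scatter), and not beyond the scatter. Compound 3 is therefore estimated at 0.4 h, with a range from 0.18 h to 0.9 h.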

Compound 3, half-life: 2.23 h
Compound 3: the middle estimate sits 5.6-fold (0.75 log units) below what was measured; measured number above the stated range.
By their numbers in this assay, from the lowest: compounds 2 and 1 (each within the scatter of the next); then compound 3.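

In this assay, the aromatic carbon next to the ring nitrogen and the ring oxygen turns out to be a place where the half-life can move well beyond the scatter, something the earlier pair could not show: the swap of cyano for cyclopropyl gives a 7.9-fold higher number from compound 2 to compound 3 (0.90 log units; beyond the scatter) and the swap of methyl for cyclopropyl gives a 5.0-fold higher number from compound 1 to compound 3 (0.70 log units; beyond the scatter). Methyl and cyano remain within the scatter of each other, so among the three groups only cyclopropyl separates from the rest, and compound 3 is the longest-lived of the three, with steps to both others printed as beyond the scatter. The data shown offer no evidence on why the half-life rises with this change.

Going by these compounds, what an isopropyl or a cyclobutyl group would do on this carbon stays open, and with it whether the rise goes with the three-membered ring itself or with carbon-only groups more generally. On these data alone, it is also open whether the same swap would carry the same step on a core with a shorter chain in place of the present one.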